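Removing a chloro where every measurement hit the ceiling

The compounds below may be only part of what the source reports. "The series", "measured", "known", "first", "only" and "open" are said of these compounds alone.

Compound 1 `O=C(O)c1cccc(-c2ccc(/C=C3\S/C(=N\c4ccc(Cl)cc4)N(c4ccc(Cl)cc4)C3=O)o2)c1` was tested in an ADME assay on Vero cells (Chlorocebus sabaeus) for cytotoxicity; a lower number here means that less compound is tolerated, a higher number that more compound is tolerated. In this assay compound 1 gives > 200000 nM, which is a limit of the assay rather than a number. Compound 2 `O=C(O)c1cccc(-c2ccc(/C=C3\S/C(=N\c4ccccc4)N(c4ccc(Cl)cc4)C3=O)o2)c1` gives > 200000 nM, again a limit. Compound 3 `O=C(O)c1cccc(-c2ccc(/C=C3\S/C(=N\c4ccccc4)N(c4ccc(Cl)cc4)C3=O)s2)c1` gives > 200000 nM, also a limit. The step that the two limits leave unreadable from compound 1 to compound 2 is unreadable since both ends sit at the limit of > 200000 nM in this assay, at which 3 of the 3 values shown sit. Compound 4 `O=C(O)c1cccc(-c2ccc(/C=C3\S/C(=N\c4ccc(Cl)cc4)N(c4ccccc4)C3=O)o2)c1` differs from compound 1 by hydrogen in place of chloro on an aromatic carbon. This resembles the change from compound 1 to compound 2, carried out on the other ring, and that step gave no readable size. With all three measured values at the same limit, no change beyond the scatter is expected. Compound 4 is therefore estimated at 200000 nM, between 100000 nM and 400000 nM. The expected step of a number no higher from compound 1 to compound 4 (the limit leaves the size open) is none beyond the scatter, most likely reported again only as a limit.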

Compound 4, half-maximal cytotoxic concentration: > 200000 nM
Compound 4 gave a limit, no number (the forecaster's own chance of this, stated with the estimate: 85%); the middle value lies on the limit itself.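

Within the data shown here, compound 1 and compound 4 sit at the same limit, so no step between them can be read: the limit of > 200000 nM in this assay, at which 4 of the 4 values shown sit. Whether removing either chloro changes how well the cells tolerate these compounds stays open, as none of the compounds shown gives an actual number.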